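Removing the (methylsulfonyl)methyl group from compound 1

The source may hold more compounds than are shown below. What is called first, only, known or untested is meant among the compounds shown, and "the series" means these compounds.

Measured compounds:
Compound 1 `CS(=O)(=O)Cc1cc([C@]23CCOC[C@H]2C3)nc(-c2cccc(O)c2)n1`: 75 ug/mL
Compound 2 `CS(=O)(=O)Cc1cc(C2=CCOCC2)nc(-c2cccc(O)c2)n1`: 27 ug/mL
Compound 3 `CNCC(=O)Nc1ccc(-c2nc(C(C)(C)S(C)(=O)=O)cc([C@@]34CCOC[C@@H]3C4)n2)cc1`: 257 ug/mL

All three were measured in a physicochemical assay for solubility, in phosphate buffer, measured as kinetic solubility, with a stated time of 1 h, at pH 7.4; on this read-out lower numbers stand for lower solubility and higher numbers for higher solubility. Compound 1 stands second highest of the three numbers; its nearest neighbour is compound 2 with 27 ug/mL, and furthest away is compound 3 with 257 ug/mL. Going by the values given here, the one single-point step among them, a 2.8-fold lower number from compound 1 to compound 2 (0.44 log units; beyond the scatter), concerns a change at another position of the shared core and is modest.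

Compound 4 `Oc1cccc(-c2nccc([C@]34CCOC[C@H]3C4)n2)c1` has not yet been measured. It differs from compound 1 by hydrogen in place of (methylsulfonyl)methyl on an aromatic carbon. Among the compounds with values here, no measured step bears on this change: the step from compound 1 to compound 2 alters a different group, and compound 3 differs from compound 1 in more than one place. The expectation for compound 4 therefore rests on the value of compound 1 alone, and a wide range is given. Compound 4 is expected to show a step of a 1.9-fold lower number from compound 1 to compound 4 (0.27 log units; within the scatter), a modest decrease that may still fall within the scatter. The estimate for compound 4 is 40 ug/mL, with a range from 12 ug/mL to 130 ug/mL.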

Compound 4, solubility: 141 ug/mL
The estimate for compound 4 lay 3.5-fold (0.55 log units) below the measured number, outside the stated range (above it).
By their numbers in this assay, from the lowest: compound 2; then compounds 1, 4 and 3 (each within the scatter of the next, the first and the last beyond it).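

In this assay, hydrogen in place of (methylsulfonyl)methyl on this aromatic carbon, next to the ring nitrogen, gives a 1.9-fold higher number from compound 1 to compound 4 (0.27 log units; within the scatter), so this read-out does not separate the two compounds. Compounds 1, 2 and 3 all carry a methylsulfonyl-bearing group at this place, so none of them could show that the core of compound 1 gives a reading within the scatter of its parent with no heavy atom there at all. Nothing available here accounts for this result.

As far as these compounds go, whether an amine, a carboxylic acid or a longer chain at this place would also stay within the scatter of compound 1 remains open. Going by these compounds alone, only one pair speaks to this change, so it is also open whether hydrogen here would read the same alongside the ring group of compound 2.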